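Saturating the ester-bearing chain: working notes

This account rests on a few compounds, and the source may have more. Where it says the series, first, only, none or still open, it means among the compounds named here.

Measured so far:
compound 1 `CCCC[C@](C)(OC)[C@@H](O)/C=C/C1[C@H](O)CC(=O)[C@@H]1CCCCCCC(=O)OC` — a limit only, > 2.5 mg/kg; > 2.5 mg/kg (2 entries)
compound 2 `CCCC[C@@](C)(OC)[C@@H](O)/C=C/C1[C@H](O)CC(=O)[C@@H]1C/C=C\CCCC(=O)OC` — a limit only, > 1 mg/kg

In a functional assay on the whole organism (Cricetulus griseus) with Cricetinae gen. sp. as the target (a higher number here means that more compound is needed for the effect, a lower number that less compound is needed), compound 2 is known only as a limit, (the limit of > 1 mg/kg in this assay, at which 1 of the 2 values shown sits), with no single number. Compound 3 `CCCC[C@@](C)(OC)[C@@H](O)/C=C/C1[C@H](O)CC(=O)[C@@H]1CCCCCCC(=O)OC` has not been measured. It differs from compound 2 by 5-(methoxycarbonyl)pentyl in place of 5-(methoxycarbonyl)pent-1-en-1-yl on a saturated chain carbon bound to a saturated ring carbon. For the measured compounds named here, no measured pair shows this change, so its size cannot be read from the present data. For compound 3 the step that the limit leaves unreadable from compound 2 to compound 3 is expected to be none beyond the scatter. Compound 3 is thus estimated at 3 mg/kg, with a range from 1 mg/kg to 10 mg/kg, and a limit rather than a number is quite likely again.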

Compound 3, dose for half-maximal effect: > 2.5 mg/kg
Compound 3 ended at the assay's limit; the forecaster's own chance of this, stated with the estimate: 70%; the middle value is on the limit's open side.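

For the compounds shown here, compound 2 and compound 3 both stand only as limits in this assay, and no step between them can be read. Still open, as far as these compounds go, is whether 5-(methoxycarbonyl)pentyl in place of 5-(methoxycarbonyl)pent-1-en-1-yl changes the dose needed at all: compounds 1, 2 and 3 give no single number.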